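The compounds below may be only part of what the source reports. "The series", "measured", "known", "first", "only" and "open" are said of these compounds alone.

Measured in an ADME assay on BaF3 cells (Mus musculus) for antiproliferative activity, read by CCK-8 assay, with a stated time of 72 h; on this read-out higher numbers stand for weaker inhibition of growth and lower numbers for stronger inhibition of growth:
- compound 1 `O=C(CCSc1ccc2c(/C=C/c3ccccn3)n[nH]c2c1)Nc1cccc(C(F)(F)F)c1`: 2300 nM
- compound 2 `CCN1CCN(Cc2ccc(NC(=O)CCSc3ccc4c(/C=C/c5ccccn5)n[nH]c4c3)cc2C(F)(F)F)CC1`: 840 nM

Compound 2 has the lower of the two numbers, so it inhibits growth more strongly than compound 1. Going by the values given here, only one measured step bears on what follows: a 2.7-fold lower number from compound 1 to compound 2 (0.44 log units; beyond the scatter), which came with (4-ethylpiperazin-1-yl)methyl in place of hydrogen on an aromatic carbon.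

Compound 3 `CC1CCN(Cc2ccc(NC(=O)CCSc3ccc4c(/C=C/c5ccccn5)n[nH]c4c3)cc2C(F)(F)F)CC1` differs from compound 2 in one place, with 4-methylpiperidin-1-yl in place of 4-ethylpiperazin-1-yl on a saturated chain carbon bound to an aromatic carbon. Among the compounds with values here, each group holds one six-membered non-aromatic ring, and no measured pair isolates this swap. Going by that single modest step, no clear direction and probably no change beyond the scatter is expected in this assay. The expected step is a 1.0-fold higher number from compound 2 to compound 3 (0.01 log units; within the scatter). For compound 3 the estimated value is 850 nM, with an expected range of 320 nM to 2200 nM.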

Compound 3, concentration for 50% growth inhibition: 4170 nM
Estimate against measurement, compound 3: 4.9-fold (0.69 log units) below; measured number outside the range, above it.
By their numbers in this assay, from the lowest: compound 2; then compounds 1 and 3 (each within the scatter of the next).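

In this assay, the group on a saturated chain carbon bound to an aromatic carbon clearly matters: changing 4-ethylpiperazin-1-yl to 4-methylpiperidin-1-yl gives a 5.0-fold higher number from compound 2 to compound 3 (0.70 log units; beyond the scatter), even though each group holds one six-membered non-aromatic ring. The earlier improvement therefore does not extend to every such ring: 4-ethylpiperazin-1-yl gave a 2.7-fold lower number from compound 1 to compound 2 (0.44 log units; beyond the scatter), whereas the (4-methylpiperidin-1-yl)methyl group gives only a 1.8-fold higher number from compound 1 to compound 3 (0.26 log units; within the scatter), which lies within the scatter. Nothing measured here explains why the two groups differ.

The swap changes the ring nitrogen count and the alkyl group together, so the compounds shown leave open which of these changes matters. A 4-methylpiperazin-1-yl group at the same place would separate them, and a morpholin-4-yl group would test a ring oxygen in place of the second nitrogen.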